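From Benzyloxy to Trifluoromethoxy on Compound 3

This account rests on a few compounds, and the source may have more. Where it says the series, first, only, none or still open, it means among the compounds named here.

Measured in an ADME assay on L929 cells (Mus musculus) for cytotoxicity; a lower number here means a stronger inhibitor, a higher number a weaker inhibitor:
- Compound 1 `O=[N+]([O-])c1cn2c(n1)OC[C@@H](NCc1ccc(OC(F)(F)F)cc1)C2` gives > 10 ug/mL.
- Compound 2 `CN1CC(OCc2ccc(OCc3ccccc3)cc2)Cn2nc([N+](=O)[O-])cc21` gives > 10 ug/mL.
- Compound 3 `O=[N+]([O-])c1cn2c(n1)S(=O)(=O)CC(OCc1ccc(OCc3ccccc3)cc1)C2` gives > 10 ug/mL.

Each of these entries is a limit and not a number. Compound 3 thus has no exact position among the others, and the series shares one reading: the limit of > 10 ug/mL in this assay, at which 3 of the 3 values shown sit.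

Compound 4 `O=[N+]([O-])c1cn2c(n1)S(=O)(=O)CC(OCc1ccc(OC(F)(F)F)cc1)C2` has trifluoromethyl in place of benzyl on an oxygen on an aromatic ring. Among the compounds with values here, no measured pair shows this change. Compound 1 also carries trifluoromethoxy and gives > 10 ug/mL, again a limit. In this assay, no step beyond the scatter is expected, in either direction. The estimated change is a step that the limit leaves unreadable from compound 3 to compound 4. For compound 4 the expected value is 20 ug/mL, with an estimated range of 10 ug/mL to 60 ug/mL.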

Compound 4, half-maximal inhibitory concentration: > 10 ug/mL
Compound 4: only a limit was reported; the forecaster's own chance of this, stated with the estimate: 85%; the middle value lies beyond the limit too.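

Compound 3 and compound 4 are both reported only as limits, so no step can be read between them: the limit of > 10 ug/mL in this assay, at which 4 of the 4 values shown sit. The compounds shown leave open how far any of them lies beyond that limit.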